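A smaller group on the carbonyl of compound 3

A few compounds are considered here, and "the series" means these few. Any claim that something is new, unique, unknown or untested is made for them only; others in the source may bear on it.

Values in a functional assay on MCF7 cells (Homo sapiens) for antiproliferative activity, read by MTT assay, with a stated time of 48 h; a higher number here means a weaker inhibitor, a lower number a stronger inhibitor:
- Compound 1 `CCN(CC)CCNC(=O)c1ccc(C(CC)(CC)c2ccc(OCCC(O)(CC)CC)c(C)c2)n1CC`: 550 nM
- Compound 2 `CCn1c(C(=O)NCC#N)ccc1C(CC)(CC)c1ccc(OCCC(O)(CC)CC)c(C)c1`: > 50000 nM, a limit and not a number
- Compound 3 `CCn1c(C(=O)N(CCC#N)CCC#N)ccc1C(CC)(CC)c1ccc(OCCC(O)(CC)CC)c(C)c1`: > 50000 nM, a limit and not a number

Only compound 1 has a true number here. Compound 3 has none: it stands at the limit of > 50000 nM in this assay, at which 2 of the 3 values shown sit.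

Compound 4 `C=CCN(C)C(=O)c1ccc(C(CC)(CC)c2ccc(OCCC(O)(CC)CC)c(C)c2)n1CC` differs from compound 3 in one place: a group of 5 heavy atoms (4 carbon, 1 nitrogen; no ring) in place of a group of 9 heavy atoms (6 carbon, 3 nitrogen; no ring), on a carbonyl carbon. The new group is allyl(methyl)amino, and it sits on a carbonyl carbon.

Among the compounds with values here, two measured steps bear on this change. Both alter the group on that same carbonyl carbon. Both are large: an at least 90-fold higher number from compound 1 to compound 2 (1.95 log units; beyond the scatter) and an at least 90-fold higher number from compound 1 to compound 3 (1.95 log units; beyond the scatter). A third, a step that the two limits leave unreadable from compound 2 to compound 3, cannot be read, so it gives no guide to size.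

Within the data shown here, in these three compounds, then, changes to this group have gone with a large loss in this assay, and only one true number is available. On the strength of an at least 90-fold higher number from compound 1 to compound 3 (1.95 log units; beyond the scatter), compound 4 is expected to stay at or close to the limit. Any readable change should be modest and towards a lower number, since the limit leaves room only in that direction.

The expected step is an at least 1.6-fold lower number from compound 3 to compound 4 (0.22 log units; that floor lies within the scatter). For compound 4 the estimated value is 30000 nM, with an expected range from 6000 nM to 50000 nM.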

Compound 4, half-maximal inhibitory concentration: > 50000 nM
Compound 4 ended at the assay's limit; the forecaster's own chance of this, stated with the estimate: 55%; at least 1.6-fold (0.22 log units) between middle value and limit.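

Compound 4 puts allyl(methyl)amino on the carbonyl carbon, a group with no nitrile, and in this assay its value is still only a limit, so a nitrile in this group is not needed for a compound to land there: the limit of > 50000 nM in this assay, at which 3 of the 4 values shown sit.

Within the data shown here, the one readable step is an at least 90-fold higher number from compound 1 to compound 4 (1.95 log units; beyond the scatter), with allyl(methyl)amino in place of (2-(diethylamino)ethyl)amino. The steps to compound 4 from compound 2 and from compound 3 cannot be read, as both ends of each are limits, and so these three compounds cannot be put in any order.

Among these compounds, compound 1 remains the only compound here with a true number, and a single value cannot say which part of its (2-(diethylamino)ethyl)amino group matters: the amide hydrogen, the chain or the diethylamino end. As far as these compounds go, it also remains open how a dimethylamino end, a longer chain before the diethylamino end, or a carboxylic acid in its place would read in this assay.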